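The source may hold more compounds than are shown below. What is called first, only, known or untested is meant among the compounds shown, and "the series" means these compounds.

Measured compounds:
- compound 1 `CCCCSC(=S)C1=C(Nc2ccc(Cl)cc2)CC(C)(C)CC1=O`: > 100 ug/mL
- compound 2 `CCCCCCCCCCCSC(=S)C1=C(Nc2ccc(Cl)cc2)CC(C)(C)CC1=O`: > 100 ug/mL

In a functional assay on cells (blood, Homo sapiens) for inhibition, read by chemiluminescence, with a stated time of 30 min (a lower number here means a stronger inhibitor, a higher number a weaker inhibitor), compound 1 gives > 100 ug/mL, which is a limit of the assay. Compound 2 gives > 100 ug/mL, also a limit. The step that the two limits leave unreadable from compound 1 to compound 2 therefore cannot be read. Compound 3 `CC1(C)CC(=O)C(C(=S)SCc2ccccc2)=C(Nc2ccc(Cl)cc2)C1` differs from compound 2 by phenyl in place of decyl on a saturated chain carbon bound to a sulfur. Among the measured compounds shown here, no measured step bears on this change; both values shown sit at the limit of > 100 ug/mL in this assay, at which 2 of the 2 values shown sit, and compound 2 stands at that limit. The step that the limit leaves unreadable from compound 2 to compound 3 is thus expected to remain unreadable. Compound 3 is expected to give 120 ug/mL, within 50 ug/mL to 300 ug/mL, most likely again only a limit.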

Compound 3, half-maximal inhibitory concentration: > 100 ug/mL
Compound 3: a limit, no number; the forecaster's own chance of this, stated with the estimate: 85%; the middle value does not contradict the limit.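

Compound 1, compound 2 and compound 3 all give only a limit in this assay, so no step among them can be read: the limit of > 100 ug/mL in this assay, at which 3 of the 3 values shown sit.

The compounds shown leave open how strongly each one inhibits, and whether exchanging these groups changes that at all.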